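Where Compound 2 Stands Before Compound 3

A few compounds are considered here, and "the series" means these few. Any claim that something is new, unique, unknown or untested is made for them only; others in the source may bear on it.

Measured so far in a functional assay on MCF7 cells (Homo sapiens) for antiproliferative activity, read by sulforhodamine B assay, with a stated time of 48 h; on this read-out higher numbers stand for weaker inhibition and lower numbers for stronger inhibition:
Compound 1 (`O=C1NCCN1c1ccc(S(=O)(=O)Nc2cccc(Br)c2)cc1`) gives 100 nM
Compound 2 (`Cc1ccc(NS(=O)(=O)c2ccc(N3CCNC3=O)cc2)c(C)c1`) gives 230 nM

Of these two numbers, compound 2 holds the higher, at 230 nM on this read-out. Its nearest and only neighbour is compound 1, and the gap between them is modest but beyond the scatter (a 2.3-fold higher number from compound 1 to compound 2 (0.36 log units; beyond the scatter)).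

Compound 3 (`COc1cccc(NS(=O)(=O)c2ccc(N3CCNC3=O)cc2)c1`) has not yet been measured. It has 3-methoxyphenyl in place of 2,4-dimethylphenyl on a sulfonamide nitrogen.

Within the data shown here, one measured step bears on this change, and it sits at the same place on the sulfonamide nitrogen (a 2.3-fold higher number from compound 1 to compound 2 (0.36 log units; beyond the scatter)). In that step, 3-bromophenyl gave way to the same 2,4-dimethylphenyl that compound 3 now loses. Leaving 2,4-dimethylphenyl might therefore recover part of that modest gap, though a single step is thin evidence, and no methoxy compound has been measured. A small step to a lower number is expected in this assay (a 1.4-fold lower number from compound 2 to compound 3 (0.16 log units; within the scatter)). The estimated value for compound 3 is 160 nM (estimated range 70 nM to 380 nM).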

Compound 3, half-maximal inhibitory concentration: 120 nM
Compound 3: the middle estimate sits 1.3-fold (0.12 log units) above what was measured; the range from low to high includes it.
By their numbers in this assay, from the lowest: compounds 1, 3 and 2 (each within the scatter of the next, the first and the last beyond it).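

In this assay, the change from 2,4-dimethylphenyl to 3-methoxyphenyl on the sulfonamide nitrogen stays inside the scatter (a 1.9-fold lower number from compound 2 to compound 3 (0.28 log units; within the scatter)), even though the entering group carries 1 hydrogen-bond acceptor and the leaving group carries 0. The comparison with compound 1 adds a second reading at this position, since methoxy in place of bromo on an aromatic carbon also stays inside the scatter (a 1.2-fold higher number from compound 1 to compound 3 (0.08 log units; within the scatter)), so these two groups cannot be told apart here, and compound 3 cannot be placed firmly with either compound 1 or compound 2, although those two are separated by more than the scatter. No available evidence gives a reason for these results.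

The three compounds leave open whether this tolerance extends to an amine or a carboxylic acid in place of methoxy on the aromatic carbon, or to a longer chain such as ethoxy. They also leave open whether the small separation seen for 2,4-dimethylphenyl would hold for a phenyl ring bearing a single methyl group.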